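The source may report more compounds than this note shows. Statements on the series, on what has been measured and on what is new or still open speak of the compounds shown alone.

Working notes on the series

Compound 1, `CC(C)n1nc(C(=O)N[C@H]2COc3ccccc3N(C)C2=S)nc1Cc1ccccc1`, sets the reference point of the series in a toxicity assay on HT-29 cells (Homo sapiens) for cytotoxicity; on this read-out higher numbers stand for lower toxicity in this test and lower numbers for higher toxicity in this test. Compound 1 gives > 100000 nM, which is a limit of the assay rather than a number. Its closest measured neighbour is compound 2, `CN1C(=S)[C@@H](NC(=O)c2nc(Cc3ccccc3)n(C3CCC3)n2)COc2ccccc21`, which in this assay gives > 100000 nM, again a limit of the assay. Going by the values given here, the one measured step, a step that the two limits leave unreadable from compound 1 to compound 2, cannot be sized because of the limit of > 100000 nM in this assay, at which 2 of the 2 values shown sit.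

The compound still to be measured is compound 3, `CN1C(=S)[C@@H](NC(=O)c2nc(Cc3ccccc3)n(C3CCCCCC3)n2)COc2ccccc21`. Relative to compound 1 the change is cycloheptyl in place of isopropyl on an aromatic nitrogen. This is the same kind of change as the measured step, an exchange at the aromatic nitrogen of the core of compound 1, carried further in size. That step gave no readable size, so it offers no direction for the new step, only the observation that both measured compounds sit at the limit of this assay.

Compound 3 is therefore expected to stay near the same limit, with a step of a number no higher from compound 1 to compound 3 (the limit leaves the size open). The estimate for compound 3 in this assay is 100000 nM, with a range from 30000 nM to 300000 nM.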

Compound 3, half-maximal cytotoxic concentration: > 100000 nM
Compound 3: no number, only a limit (the forecaster's own chance of this, stated with the estimate: 65%); the middle value sits exactly at the limit.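

No new step can be read, as the changes from compound 1 and from compound 2 to compound 3 both stay without a size, because all values rest on one limit: the limit of > 100000 nM in this assay, at which 3 of the 3 values shown sit.

The compounds shown leave open whether isopropyl, cyclobutyl and cycloheptyl on the aromatic nitrogen differ at all in this assay.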